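The source may hold more compounds than are shown below. What is called first, only, known or untested is meant among the compounds shown, and "the series" means these compounds.

Working notes on the series in an assay on isolated protein for inhibition of Neuropeptide Y receptor type 5 (Homo sapiens); on this read-out lower numbers stand for stronger inhibition and higher numbers for weaker inhibition.

Compound 1 `O=S(=O)(NCCN1CCC(CNC2CCCc3ccc(Cl)cc3C2)CC1)c1cccc2ccccc12` gives 85 nM in this assay. Compound 2 `O=[N+]([O-])c1ccc2c(c1)CC(NCC1CCN(CCNS(=O)(=O)c3cccc4ccccc34)CC1)CCC2` gives 79 nM in this assay. Going by the values given here, the only measured step, a 1.1-fold lower number from compound 1 to compound 2 (0.03 log units; within the scatter), so compound 2 and compound 1 sit within the scatter of each other and neither can be ranked against the other on these numbers.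

Compound 3 `CCOC(=O)COc1ccc2c(c1)CC(NCC1CCN(CCNS(=O)(=O)c3cccc4ccccc34)CC1)CCC2` has not yet been measured in this assay. It differs from compound 2 in one place: (ethoxycarbonyl)methoxy in place of nitro on an aromatic carbon. Among the compounds with values here, no measured step bears directly on this change; the one step available, a 1.1-fold lower number from compound 1 to compound 2 (0.03 log units; within the scatter), concerns a different exchange at the same aromatic carbon and stayed within the scatter, so it gives no direction for the present case.

For compound 3 the expected step is a 1.9-fold higher number from compound 2 to compound 3 (0.28 log units; within the scatter), a modest move toward a higher number that may or may not clear the scatter. Compound 3 is therefore estimated at 150 nM, with a range from 50 nM to 500 nM.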

Compound 3, half-maximal inhibitory concentration: 680 nM
For compound 3 the middle estimate is 4.5-fold (0.66 log units) below the measured one, and the stated range ends below it.
By their numbers in this assay, from the lowest: compounds 2 and 1 (each within the scatter of the next); then compound 3.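

In this assay this aromatic carbon does respond to the group it carries: the exchange of nitro for (ethoxycarbonyl)methoxy gives an 8.6-fold higher number from compound 2 to compound 3 (0.93 log units; beyond the scatter) and the exchange of chloro for the same group gives an 8.0-fold higher number from compound 1 to compound 3 (0.90 log units; beyond the scatter) on the shared core. Nitro and chloro could not be told apart, so these steps give the first direction at this position, toward a higher number, with 7 heavy atoms entering where nitro had 3. No measurement on hand accounts for this shift.

Still open, on these data alone, is which part of the entering group goes with the higher number, the ether oxygen, the ester or the ethyl end. A plain methoxy, the corresponding carboxylic acid or an amine at this aromatic carbon would separate these parts.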